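Cyclohexyl in Place of Aminophenyl on a Thioether Sulfur

A few compounds are considered here, and "the series" means these few. Any claim that something is new, unique, unknown or untested is made for them only; others in the source may bear on it.

Of the compounds shown here, three have been tested in a functional assay on U2OS cells (Homo sapiens) for antiproliferative activity, read by MTT assay, with a stated time of 72 h; on this read-out lower numbers stand for stronger inhibition and higher numbers for weaker inhibition. Compound 1 `Nc1ccc(SCC(=O)Nc2ccc3nc(NC(=O)c4ccc(C(F)(F)F)cc4)sc3c2)cc1` gives 1220 nM, the lowest of the two numbers obtained. Compound 3 `Oc1ccc(Cl)cc1/C=N/c1ccc(-c2nc3ccccc3o2)c(O)c1` gives 21700 nM, a far higher number that lies beyond the usual scatter. Compound 2 `Cc1cc(C)cc(C(=O)Nc2nc3ccc(NC(=O)CSc4ccc(Cl)cc4)cc3s2)c1` gives > 100000 nM, which is a limit of the assay rather than a measured number. That value is the limit of > 100000 nM in this assay, at which 1 of the 3 values shown sits.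

Compound 4 `O=C(CSC1CCCCC1)Nc1ccc2nc(NC(=O)c3ccc(C(F)(F)F)cc3)sc2c1` has not yet been measured. It differs from compound 1 in one place: cyclohexyl in place of 4-aminophenyl on a sulfur. For the measured compounds named here, no measured pair shows this kind of change, so the step from compound 1 is expected to be modest, probably toward a higher number, about a 2.0-fold higher number from compound 1 to compound 4 (0.31 log units; beyond the scatter). Compound 4 is therefore estimated at 2500 nM, within 800 nM to 8000 nM.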

Compound 4, half-maximal inhibitory concentration: 12300 nM
Estimate against measurement, compound 4: 4.9-fold (0.69 log units) below; the whole stated range lies below it.
By their numbers in this assay, from the lowest: compound 1; then compounds 4 and 3 (each within the scatter of the next). At a limit, above all of these: compound 2.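

In this assay, the group on this sulfur clearly matters: cyclohexyl in place of 4-aminophenyl gives a 10-fold higher number from compound 1 to compound 4 (1.00 log units; beyond the scatter) and lies beyond the scatter. The change replaces an aromatic ring carrying a hydrogen-bond donor and acceptor with a non-aromatic carbon ring carrying neither. No measurement shown here explains the step or says which of these differences matters.

Plain phenyl on the same sulfur would separate the loss of the amine from the loss of the aromatic ring. A 4-aminocyclohexyl group would put the amine back on the non-aromatic ring.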